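Thiosemicarbazone series: chloro to nitro on the benzylidene ring

This account rests on a few compounds, and the source may have more. Where it says the series, first, only, none or still open, it means among the compounds named here.

Measured compounds:
compound 1 `CC1=CC[C@H](C(C)(C)NC(=S)N/N=C/c2ccccc2Cl)CC1`, 98000 nM
compound 2 `CC1=CC[C@H](C(C)(C)NC(=S)N/N=C/c2cccc(Cl)c2)CC1`, 39800 nM
compound 3 `CC1=CC[C@H](C(C)(C)NC(=S)N/N=C/c2ccccc2[N+](=O)[O-])CC1`, 92200 nM

All three share one core and differ only in the substituted phenyl on the carbon with a double bond to nitrogen. In a functional assay on UACC-62 cells (Homo sapiens) for inhibition, read by sulforhodamine B assay, with a stated time of 48 h (on this read-out higher numbers stand for weaker inhibition of growth and lower numbers for stronger inhibition of growth), compound 1 gives 98000 nM and stands at the high end of the set. Compound 2 gives the lowest number of the three in this assay; the two cores differ as follows: 3-chlorophenyl in place of 2-chlorophenyl on a carbon with a double bond to nitrogen, and the step is a 2.5-fold lower number from compound 1 to compound 2 (0.39 log units; beyond the scatter). Compound 3 gives 92200 nM in this assay; its difference from compound 1 is nitro in place of chloro on an aromatic carbon, and the step is a 1.1-fold lower number from compound 1 to compound 3 (0.03 log units; within the scatter), so the chloro-to-nitro swap at that place left the number essentially where it was.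

Compound 4 `CC1=CC[C@H](C(C)(C)NC(=S)N/N=C/c2cccc([N+](=O)[O-])c2)CC1` is not yet measured. Its difference from compound 2 is nitro in place of chloro on an aromatic carbon. This is the same kind of change as that from compound 1 to compound 3, though not the same: in compound 3 the nitro sits ortho to a large group, whereas in compound 4 it sits meta to a large group. For the measured compounds named here, with only one prior instance of the swap, the expectation rests on that single step, a 1.1-fold lower number from compound 1 to compound 3 (0.03 log units; within the scatter), together with the value of compound 2, 39800 nM. The step from compound 2 to compound 4 in this assay is expected to be small, about a 1.1-fold lower number from compound 2 to compound 4 (0.04 log units; within the scatter). Compound 4 is accordingly estimated at 36000 nM, with a likely range from 18000 nM to 80000 nM.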

Compound 4, concentration for total growth inhibition: > 100000 nM
Compound 4: only a limit was reported; the forecaster's own chance of this, stated with the estimate: 10%; middle value at least 2.7-fold (0.44 log units) from the limit.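

In this assay compound 4 is reported only as a limit, > 100000 nM. With the group meta to a large group, nitro in place of chloro gives an at least 2.5-fold higher number from compound 2 to compound 4 (0.40 log units; beyond the scatter), so on this core the swap does not leave the number where it was, and the lowest number in the set belongs to the chloro compound, not its nitro counterpart. This single pair does not show that the swap behaves differently on the two cores, nor does it show that it carries over unchanged, and no size can be given for the step on the core of compound 2, only a lower bound: the same change on two cores in this assay, a 1.1-fold lower number (0.03 log units; within the scatter) from compound 1 to compound 3 and an at least 2.5-fold higher number (0.40 log units; beyond the scatter) from compound 2 to compound 4; the limit leaves it open whether they differ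

From the compounds shown here alone, how far compound 4 lies past its limit stays open, and with it whether the swap has any real dependence on where the group sits on the phenyl ring. The compounds shown cover only chloro and nitro at two places on that ring, so how a methoxy group, an amine or a carboxylic acid would read at those places, and whether any of them would bring the number below that of compound 2, also remains open.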